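The source may hold more compounds than are shown below. What is called first, only, known or untested is meant among the compounds shown, and "the series" means these compounds.

Compound 2 `C=C(C/C(=C\c1ccc(Cl)cc1)C(=O)c1ccccc1)C(=O)c1ccccc1` is one of two compounds measured in a functional assay on WiDr cells (Homo sapiens) for inhibition, read by sulforhodamine B assay, with a stated time of 48 h; a lower number here means a stronger inhibitor of growth, a higher number a weaker inhibitor of growth; there compound 2 gives 20000 nM, the higher of the two numbers shown. Compound 1 `O=C(OC/C(=C\c1ccc(Cl)cc1Cl)C(=O)c1ccccc1)c1ccccc1` gives 17000 nM, and the gap between the two numbers lies within the scatter of repeated measurements, so the two values tell the same story. Compound 3 `C=C(C/C(=C\c1ccccc1F)C(=O)c1ccccc1)C(=O)c1ccccc1` has not yet been measured. It differs from compound 2 in one place: 2-fluorophenyl in place of 4-chlorophenyl on a double-bonded chain carbon bound to a double-bonded chain carbon. Within the data shown here, no measured pair shows this exchange, so its effect cannot be read from the data, and both measured compounds sit at high concentrations where growth inhibition is weak. The expected step of a 1.3-fold higher number from compound 2 to compound 3 (0.10 log units; within the scatter) in this assay is small, likely not beyond the scatter, in either direction. Compound 3 is therefore estimated to give about 25000 nM, with a range from 8000 nM to 80000 nM.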

Compound 3, concentration for 50% growth inhibition: 17000 nM
Estimate against measurement, compound 3: 1.5-fold (0.17 log units) above; the measured number falls inside the stated range.
By their numbers in this assay, from the lowest: compounds 1, 3 and 2 (each within the scatter of the next).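

Among these compounds, putting 2-fluorophenyl in place of 4-chlorophenyl, on a double-bonded chain carbon bound to a double-bonded chain carbon, gives the first direct comparison at this position, and in this assay it amounts to a 1.2-fold lower number from compound 2 to compound 3 (0.07 log units; within the scatter). This exchange of one halogen-carrying phenyl group for another therefore does not separate the two compounds, and both remain at high concentrations where growth inhibition is weak. No available measurement explains this outcome.

From the compounds shown here alone, the phenyl groups at this place in compound 2 and compound 3 carry only chlorine or fluorine, so the effect on growth inhibition of an amine or a carboxylic acid there remains open. It is also unknown whether any single exchange at this position can produce a step beyond the scatter.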